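The compounds below may be only part of what the source reports. "The series", "measured", "known", "first", "only" and "open" are said of these compounds alone.

A small set of related compounds has been tested in a functional assay on HepG2 cells (Homo sapiens) for antiproliferative activity, read by MTT assay, with a stated time of 72 h; a lower number here means a stronger inhibitor, a higher number a weaker inhibitor. There, compound 1 `NC1=NC2(CCSCC2)N(OCCCOc2ccc(Cl)c(Cl)c2)C(N)=N1` gives 70 nM, the lowest of the two numbers available. Compound 2 `NC1=NC2(CCOCC2)N(OCCCOc2cccc(Cl)c2Cl)C(N)=N1` gives 330 nM, a higher number by a margin beyond the usual scatter. It differs from compound 1 in more than one place, so the gap cannot be tied to any single change. Compound 3 `NC1=NC2(CCOCC2)N(OCCCOc2ccc(F)cc2)C(N)=N1` has the entry "not determined" (no result reported) and adds no number.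

Compound 4 `NC1=NC2(CCSCC2)N(OCCCOc2cc(Cl)c(Cl)cc2Cl)C(N)=N1` has not yet been measured. It departs from compound 1 in one place: chloro in place of hydrogen on an aromatic carbon. A chloro takes the place of a hydrogen on an aromatic carbon, so 3,4-dichlorophenyl becomes 2,4,5-trichlorophenyl. Among the measured compounds shown here, no measured pair shows this kind of swap on its own, so the judgement rests on thin evidence. In this assay, the expectation is a small shift towards a higher number, possibly none beyond the scatter. For the measured compounds named here, the only other number, from compound 2 at 330 nM, suggests that this set can lose ground from compound 1, but it does not fix the size of this step. The expected step is a 1.6-fold higher number from compound 1 to compound 4 (0.20 log units; within the scatter). For compound 4 the estimated value is 110 nM, with an expected range from 35 nM to 350 nM.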

Compound 4, half-maximal inhibitory concentration: > 100000 nM
Compound 4 ended at the assay's limit (the forecaster's own chance of this, stated with the estimate: 3%); middle value at least 900-fold (2.95 log units) away from the limit.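

Among the compounds shown here, until now no pair of compounds isolated a single change, and this one does: in this assay, chloro in place of hydrogen on an aromatic carbon, turning 3,4-dichlorophenyl into 2,4,5-trichlorophenyl, gives an at least 1400-fold higher number from compound 1 to compound 4 (3.15 log units; beyond the scatter), a large step beyond the scatter. In this pair, then, a carbon ortho to a large group, meta to a chloro group and para to a chloro group is far from a neutral place for substitution, since one added heavy atom is enough to separate a compound with a clear measured value from one with none. Compound 4 gives > 100000 nM, which is a limit of the assay and not a number: the limit of > 100000 nM in this assay, at which 1 of the 4 values shown sits.

The compounds shown leave open whether a methyl or a methoxy group on this same aromatic carbon would cost as much as chloro, and so whether the loss is tied to chloro itself or to any group placed there. They also cannot tell why the change costs so much, or whether the same chloro would act alike with neither of the two chloro groups of compound 1 present.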